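Benzyl sulfonamide pair: nitro aryl into the methoxy amide

This account rests on a few compounds, and the source may have more. Where it says the series, first, only, none or still open, it means among the compounds named here.

Of the compounds shown here, two have numbers so far. Compound 1 `O=C(NCc1ccc(CNS(=O)(=O)c2ccc([N+](=O)[O-])cc2)cc1)c1cccnc1` gives 100 nM in an assay on MDA-MB-231 cells for displacement of a labelled ligand from C-X-C chemokine receptor type 4 (Homo sapiens), read by fluorescence and microscopy, with stated times of 10 min and 30 min; a lower number here means that less compound is needed, a higher number that more compound is needed for the effect. Compound 2 `COc1ccccc1C(=O)NCc1ccc(CNS(=O)(=O)c2cccc(F)c2)cc1` gives 1000 nM in this assay, the higher of the two numbers; the gap to compound 1 is beyond the scatter, but the two structures differ in more than one place, so no single change can be held to account. Compound 3 `COc1ccccc1C(=O)NCc1ccc(CNS(=O)(=O)c2ccc([N+](=O)[O-])cc2)cc1` carries 4-nitrophenyl in place of 3-fluorophenyl on a sulfonyl sulfur. Since compound 1 also carries the 4-nitrophenyl, a lower number than compound 2 is expected for compound 3, estimated at 300 nM, range 100 nM to 1000 nM, a step of a 3.3-fold lower number from compound 2 to compound 3 (0.52 log units; beyond the scatter) expected to lie beyond the scatter.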

Compound 3, effective concentration (reported as EC, without a stated level of effect): 100 nM
Beside the measured number, compound 3's estimate is 3.0-fold (0.48 log units) above it, within the range that was stated.
By their numbers in this assay, from the lowest: compounds 1 and 3 (each within the scatter of the next); then compound 2.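

In this assay, among the compounds shown here, the change on a sulfonyl sulfur, 4-nitrophenyl in place of 3-fluorophenyl, gives a 10-fold lower number from compound 2 to compound 3 (1.00 log units; beyond the scatter) as the first reading of this position in which only one place differs. With 4-nitrophenyl held, 2-methoxyphenyl in place of pyridin-3-yl on a carbonyl carbon gives no change at the digits printed from compound 1 to compound 3 (within the scatter) and so does not separate these two groups in this assay. Nothing measured here accounts for either step. Open, on these data alone, is whether the nitro group itself carries the first step, which 4-aminophenyl or 4-carboxyphenyl on the sulfonyl sulfur would test.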